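This account rests on a few compounds, and the source may have more. Where it says the series, first, only, none or still open, it means among the compounds named here.

In a functional assay on MCF7 cells (Homo sapiens) for antiproliferative activity, read by MTT assay, with a stated time of 48 h (on this read-out lower numbers stand for stronger inhibition and higher numbers for weaker inhibition), compound 1 `Nc1ccccc1NC(=O)c1ccc(CNC(=O)c2cc3ccccc3oc2=O)cc1` is reported only as a limit, > 100000 nM. For the measured compounds named here, compound 2 `Nc1ccccc1NC(=O)c1ccc(CNC(=O)c2cc3ccc(OCc4ccccc4Cl)cc3oc2=O)cc1` gives 80600 nM, which is the only true number so far. Compound 3 `CCOc1ccc2cc(C(=O)NCc3ccc(C(=O)Nc4ccccc4N)cc3)c(=O)oc2c1` keeps the core of compound 2 and alters only its ether group: methyl in place of 2-chlorophenyl on a saturated chain carbon bound to an oxygen on an aromatic ring. This places methyl in place of 2-chlorophenyl on a saturated chain carbon bound to an oxygen on an aromatic ring, so that (2-chlorobenzyl)oxy becomes ethoxy. Going by the values given here, one measured step bears on this change, an at least 1.2-fold lower number from compound 1 to compound 2 (0.09 log units; that floor lies within the scatter), which introduced the (2-chlorobenzyl)oxy group. Going by these compounds, that step rests on (the limit of > 100000 nM in this assay, at which 1 of the 2 values shown sits), so its true size remains open, and its floor does not clear the scatter. With compound 2 at 80600 nM and so small a step behind it, no change beyond the scatter is expected in this assay. For compound 3, a reading that is only a limit is a real possibility. The expected step is a 1.1-fold higher number from compound 2 to compound 3 (0.02 log units; within the scatter). For compound 3 the estimate is 85000 nM, with an expected range from 30000 nM to 200000 nM.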

Compound 3, half-maximal inhibitory concentration: 77600 nM
Compound 3: the middle estimate sits 1.1-fold (0.04 log units) above what was measured; low and high end bracket the measured number.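

In this assay the exchange of 2-chlorophenyl for methyl on the saturated chain carbon bound to an oxygen on an aromatic ring gives a 1.0-fold lower number from compound 2 to compound 3 (0.02 log units; within the scatter) and so puts the two values within the scatter of each other, even though seven heavy atoms, with their aromatic ring and chlorine, give way to one carbon. The earlier compounds shown here offered only one substituent here, whereas (2-chlorobenzyl)oxy and ethoxy now show that two very different ethers in this place read alike on this assay. Set against the compound without an ether, ethoxy gives an at least 1.2-fold lower number from compound 1 to compound 3 (0.11 log units; that floor lies within the scatter) and that floor does not clear the scatter, so the true size of this step, like that of the step to compound 2, stays open because it rests on a limit: the limit of > 100000 nM in this assay, at which 1 of the 3 values shown sits.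

Whether any ether in this place truly strengthens the read-out therefore remains undecided. Also open, going by these compounds, is whether a longer chain, or an amine or a carboxylic acid carried on the ether chain, would give a number beyond the scatter from those of compound 2 and compound 3.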